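A few compounds are considered here, and "the series" means these few. Any claim that something is new, unique, unknown or untested is made for them only; others in the source may bear on it.

Measured compounds and their values:
compound 1 `CC(C(=O)N1CCN(c2ccccc2C(F)(F)F)CC1)N1C(=O)CCC1=O`: 100%
compound 2 `COCC(C(=O)N1CCN(c2cccc(C(F)(F)F)c2)CC1)N1C(=O)CCC1=O`: 25%

In a functional assay on the whole organism (strain Swiss) with Mus musculus as the target, in the maximal electroshock model, with a stated time of 0.25 h, at a dose of 300 mg/kg by the intraperitoneal route (a lower number here means a weaker effect, a higher number a stronger effect of the compound at the dose given), compound 1 gives 100%, the highest of the two numbers shown. Compound 2 gives 25%, a number lower than that of compound 1 by a gap beyond the usual scatter. These two compounds differ in more than one place, so no single step between them is shown; their values only tell what each gives on its own.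

Compound 3 `CCC(C(=O)N1CCN(c2ccccc2C(F)(F)F)CC1)N1C(=O)CCC1=O` has not yet been measured. It differs from compound 1 in one place: methyl in place of hydrogen on a saturated chain carbon, two bonds along the chain from an amide-type nitrogen in a ring and a carbonyl carbon. Among the measured compounds shown here, no step of this kind between measured compounds is available, so the expectation rests on compound 1 alone. Because compound 1 already gives 100%, the read-out of compound 3 cannot rise above it, and the step of a number 10 percentage points lower from compound 1 to compound 3 (within the scatter) is expected to be small, downward or none beyond the scatter. Compound 3 is therefore estimated at 90%, with a range from 60% to 100%.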

Compound 3, a percentage reported as activity, at one dose (the size of the read-out at that dose, not a potency): 25%
Beside the measured number, compound 3's estimate is 65 percentage points above it; measured number outside the range, below it.
By their numbers in this assay, from the lowest: compounds 2 and 3 (each within the scatter of the next); then compound 1.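

In this assay, methyl in place of hydrogen on this saturated chain carbon gives a number 75 percentage points lower from compound 1 to compound 3 (beyond the scatter), so the position is sensitive to even a small change. Among the compounds shown here, until now, no single-place step had been available to show this; here, the same difference, read as methyl to ethyl, adds only 1 heavy atom, with no ring and no net charge, yet it markedly alters the read-out at the dose given. Nothing measured alongside this result offers an explanation for the drop.

The compounds shown leave open how a longer chain such as propyl, or a group such as hydroxymethyl or an amine, would read at this carbon. They also leave open whether this step would be the same on a different core.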